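The compounds below may be only part of what the source reports. "The series", "measured", "known", "first", "only" and "open" are said of these compounds alone.

The measured compounds and their numbers in a functional assay on DU-145 cells (Homo sapiens) for inhibition, read by sulforhodamine B assay, with a stated time of 48 h; a lower number here means a stronger inhibitor, a higher number a weaker inhibitor: compound 1 `CO[C@@H]1CC=C2NN(c3cc(Cl)cc(Cl)c3)C(=O)C[C@]2(C)O1` gives 21300 nM; compound 2 `CO[C@@H]1CC=C2NN(c3ccc(Cl)cc3)C(=O)C[C@]2(C)O1` gives 24200 nM; compound 3 `CO[C@@H]1CC=C2NN(c3cc(Cl)cc(Cl)c3)C(=O)C[C@]2(c2ccncc2)O1` gives 7600 nM.

Compound 2 carries the highest of the three numbers. Its nearest neighbour is compound 1, whose number is lower by a gap that lies within the scatter, so the two cannot be ordered. Compound 3 lies furthest from it, lower by a gap beyond the scatter. The only step measured among these, a 2.8-fold lower number from compound 1 to compound 3 (0.45 log units; beyond the scatter), concerns pyridin-4-yl in place of methyl on a saturated ring carbon, a site other than the one altered next.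

Compound 4 `CO[C@@H]1CC=C2NN(c3ccc(C)cc3)C(=O)C[C@]2(C)O1` differs from compound 2 in this way: methyl in place of chloro on an aromatic carbon. Among the measured compounds shown here, no measured step touches this position. The nearest comparison is compound 1 against compound 2, which differ in the chlorine count on the same aromatic ring and sit within the scatter of each other. On that basis the change to compound 4 is expected to move the number little: the estimated step of a 1.1-fold higher number from compound 2 to compound 4 (0.03 log units; within the scatter) is expected to stay within the scatter. Compound 4 is therefore estimated at 26000 nM in this assay, with a range from 11000 nM to 60000 nM.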

Compound 4, half-maximal inhibitory concentration: 23200 nM
Estimate against measurement, compound 4: 1.1-fold (0.05 log units) above; low and high end bracket the measured number.
By their numbers in this assay, from the lowest: compound 3; then compounds 1, 4 and 2 (each within the scatter of the next).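

In this assay, among the compounds shown here, the step of a 1.0-fold lower number from compound 2 to compound 4 (0.02 log units; within the scatter) gives the first direct reading of a single exchange on this aromatic ring, and it lies within the scatter. At this aromatic carbon, para to a large group, chloro and methyl therefore cannot be told apart, so the 4-chlorophenyl to 4-methylphenyl change leaves the number effectively where it was. The exchange swaps one heavy atom for one heavy atom, neither group bringing a hydrogen-bond donor or acceptor, and no accompanying evidence bears on why the two groups read alike.

The compounds shown leave open whether this flat reading would survive a group less like chloro at the same position, such as an amine, a carboxylic acid or a longer chain. They also leave open whether the gain seen in the step of a 2.8-fold lower number from compound 1 to compound 3 (0.45 log units; beyond the scatter), with pyridin-4-yl in place of methyl on a saturated ring carbon, would recur on the 4-methylphenyl compound.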